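Naphthyl replacement in a series of isatin-type antiproliferatives

This account rests on a few compounds, and the source may have more. Where it says the series, first, only, none or still open, it means among the compounds named here.

Measured so far:
- compound 1, `COc1ccc(CN2C(=O)C(=O)c3cc(-c4ccc(OC)c(OC)c4)ccc32)cc1`, 260 nM
- compound 2, `COc1ccc(CN2C(=O)C(=O)c3cc(-c4ccc(O)cc4)ccc32)cc1`, 60 nM

Within the data shown here, in a functional assay on K562 cells (Homo sapiens) for antiproliferative activity, read by MTT assay, with a stated time of 48 h (on this read-out higher numbers stand for weaker inhibition and lower numbers for stronger inhibition), compound 2 holds the lowest of the two numbers; its nearest neighbour is compound 1, and the only measured step, a 4.3-fold lower number from compound 1 to compound 2 (0.64 log units; beyond the scatter), separates them. Compound 3, `COc1ccc(CN2C(=O)C(=O)c3cc(-c4ccc5ccccc5c4)ccc32)cc1`, is not yet measured. It differs from compound 2 by naphthalen-2-yl in place of 4-hydroxyphenyl on an aromatic carbon. The step from compound 1 to compound 2 is the only one that bears on this change, and it was modest; it shows that exchanging the aryl group at this point shifts the number beyond the scatter but not greatly. Compound 3 carries neither the hydroxyl donor nor any acceptor on the aryl, so some loss against compound 2 is plausible, and a step of a 2.7-fold higher number from compound 2 to compound 3 (0.43 log units; beyond the scatter) in this assay is expected. The estimate for compound 3 in this assay is 160 nM, with a range from 45 nM to 600 nM.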

Compound 3, half-maximal inhibitory concentration: 340 nM
For compound 3 the middle estimate is 2.1-fold (0.33 log units) below the measured one; measured number inside the range.
By their numbers in this assay, from the lowest: compound 2; then compounds 1 and 3 (each within the scatter of the next).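

At this position in this assay, the gain seen with 4-hydroxyphenyl does not carry over to naphthalen-2-yl, giving (a 5.7-fold higher number from compound 2 to compound 3 (0.75 log units; beyond the scatter)). Naphthalen-2-yl and 3,4-dimethoxyphenyl read alike (a 1.3-fold higher number from compound 1 to compound 3 (0.12 log units; within the scatter)), so a second ring on the aryl group and the two methoxy groups give no separable difference here. Among these three compounds, only compound 2, the one with a hydroxyl on the aryl group, stands apart, and no measurement on hand explains this.

Still open, on these data alone, is whether the hydroxyl itself accounts for the gap, or whether the single phenyl ring also contributes. An amine or a carboxylic acid on the phenyl ring, or a hydroxyl on the naphthalen-2-yl group, would help separate these two readings.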